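The compounds below may be only part of what the source reports. "The series", "measured", "known", "first", "only" and "open" are said of these compounds alone.

Measured so far:
compound 1 `CC(C)[C@@H]1CC[C@@H](C)C[C@@]12N(C)C(=O)[C@@H]1[C@H]3C(=O)N(c4ccccc4)C(=O)[C@H]3ON12` — 29.7%
compound 2 `COc1ccc(N2C(=O)[C@H]3[C@H](ON4[C@@H]3C(=O)N(C)[C@@]43C[C@H](C)CC[C@H]3C(C)C)C2=O)cc1` — 61%

In a functional assay, read by spectrophotometry, with a stated time of 2 h, tested at 1 mg/mL (on this read-out higher numbers stand for a stronger effect at the one concentration tested and lower numbers for a weaker effect), compound 2 gives 61%, the higher of the two numbers at hand; compound 1 gives 29.7%. Within the data shown here, the single measured step, a number 31.3 percentage points higher from compound 1 to compound 2 (beyond the scatter), is the only comparison available and concerns the group on the amide-type nitrogen in a ring. Compound 3 `CC(C)[C@@H]1CC[C@@H](C)C[C@@]12N(C)C(=O)[C@@H]1[C@H]3C(=O)N(c4ccc5ccccc5c4)C(=O)[C@H]3ON12` is not yet measured. It differs from compound 2 as follows: naphthalen-2-yl in place of 4-methoxyphenyl on an amide-type nitrogen in a ring. Among the measured compounds shown here, the change removes the methoxy whose introduction made up the measured step, and at the same time brings in a second six-membered aromatic ring of carbon only, for which no measured step exists. From the compounds shown here alone, the measured step thus bears on the change only in part: reversing it would point to a loss, while the effect of the added ring is unknown and could pull either way. A downward step in this assay beyond the scatter is expected, but smaller than the measured one given the open question of the added ring. For compound 3 the expected result is 40%, within 15% to 65%, corresponding to an expected step of a number 21 percentage points lower from compound 2 to compound 3 (beyond the scatter).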

Compound 3, a percentage reported as activity, at one concentration (the size of the read-out at that concentration, not a potency): 33.2%
Estimate against measurement, compound 3: 6.8 percentage points above; the measured number falls inside the stated range.
By their numbers in this assay, from the lowest: compounds 1 and 3 (each within the scatter of the next); then compound 2.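

Across the amide-type nitrogen in a ring, the read-out in this assay does not follow the size of the aryl group: a number 27.8 percentage points lower from compound 2 to compound 3 (beyond the scatter), and the step back to the unsubstituted aryl group gives a number 3.5 percentage points higher from compound 1 to compound 3 (within the scatter). The added six-membered aromatic ring of carbon only therefore does not reproduce the number seen with 4-methoxyphenyl, and naphthalen-2-yl and phenyl cannot be told apart at this position in this assay; among these three compounds, only the 4-methoxyphenyl of compound 2 stands apart, with steps to both others beyond the scatter. Nothing available explains this difference between the groups.

Whether the higher number depends on the methoxy itself remains open, as the compounds shown do not say whether a hydroxy, an ethoxy or a chlorine in its place on the phenyl ring would give a number like that of compound 2. From the compounds shown here alone, a methoxy on the naphthalen-2-yl group is equally open, and readings at a single concentration leave the potency of all three compounds undefined.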